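This account rests on a few compounds, and the source may have more. Where it says the series, first, only, none or still open, it means among the compounds named here.

Compound 1 `COc1cc2ncnc(N3CCCc4ccccc43)c2cc1NC(=O)/C=C/CN1CCN(C)CC1` gives 8560 nM in a functional assay on MCF7 cells (Homo sapiens) for antiproliferative activity, read by MTT assay, with a stated time of 72 h; on this read-out lower numbers stand for stronger inhibition and higher numbers for weaker inhibition. Compound 2 `COc1cc2ncnc(N3CCCc4ccccc43)c2cc1NC(=O)/C=C/CN1CCC(CO)CC1` carries 4-(hydroxymethyl)piperidin-1-yl in place of 4-methylpiperazin-1-yl on a saturated chain carbon bound to a double-bonded chain carbon and in this assay compound 2 gives 5740 nM, a step of a 1.5-fold lower number from compound 1 to compound 2 (0.17 log units; within the scatter). Compound 3 `CN1CCN(C/C=C/C(=O)Nc2cc3c(N4CCCc5ccccc54)ncnc3cc2O[C@@H]2CCOC2)CC1` differs from compound 1 by oxolan-3-yl in place of methyl on an oxygen on an aromatic ring, and in this assay compound 3 gives 7180 nM, a step of a 1.2-fold lower number from compound 1 to compound 3 (0.08 log units; within the scatter). Compound 4 `O=C(/C=C/CN1CCC(CO)CC1)Nc1cc2c(N3CCCc4ccccc43)ncnc2cc1O[C@@H]1CCOC1` has not yet been measured; it differs from compound 3 by 4-(hydroxymethyl)piperidin-1-yl in place of 4-methylpiperazin-1-yl on a saturated chain carbon bound to a double-bonded chain carbon, at the same place as in the earlier pair, so it is the same change on the core of compound 3. Because the earlier step was a 1.5-fold lower number from compound 1 to compound 2 (0.17 log units; within the scatter), a similar small step is expected here, a 1.5-fold lower number from compound 3 to compound 4 (0.17 log units; within the scatter). Compound 4 is therefore estimated to give about 4800 nM, with a plausible range from 2400 nM to 9600 nM.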

Compound 4, half-maximal inhibitory concentration: 4960 nM
Compound 4: middle estimate off by 1.0-fold (0.01 log units), on the low side, and the stated range covers the measured number.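

In this assay, changing 4-methylpiperazin-1-yl to 4-(hydroxymethyl)piperidin-1-yl gives a 1.4-fold lower number from compound 3 to compound 4 (0.16 log units; within the scatter), and this step matches the earlier one on the other core: the same change on two cores in this assay, a 1.5-fold lower number (0.17 log units; within the scatter) from compound 1 to compound 2 and a 1.4-fold lower number (0.16 log units; within the scatter) from compound 3 to compound 4, 1.0-fold (0.01 log units) apart, within the scatter of two such steps. Changing methyl to oxolan-3-yl on the oxygen gives a 1.2-fold lower number from compound 2 to compound 4 (0.06 log units; within the scatter), which also matches its earlier step: the same change on two cores in this assay, a 1.2-fold lower number (0.08 log units; within the scatter) from compound 1 to compound 3 and a 1.2-fold lower number (0.06 log units; within the scatter) from compound 2 to compound 4, 1.0-fold (0.01 log units) apart, within the scatter of two such steps. Each change therefore carries over between these two cores in the sense that its step stays within the scatter on both, but this does not show that either change has a real effect on the read-out, and two cores cannot show how it would behave on others.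

On these data alone, it remains open whether another amine on that saturated chain carbon, such as morpholine or dimethylamine, would give a step beyond the scatter. The same question stands for a longer chain in place of oxolan-3-yl on the oxygen.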